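Dipropylamino to piperidin-1-yl on the shared core

The source may report more compounds than this note shows. Statements on the series, on what has been measured and on what is new or still open speak of the compounds shown alone.

Compound 1 `O=C1C=C(NCc2ccccc2)C(=O)c2c1nc1n2[C@H]2OC[C@@H](O)[C@H]2OC1`: > 8000 nM
Compound 2 `CCCN(CCC)C1=CC(=O)c2nc3n(c2C1=O)[C@H]1OC[C@@H](O)[C@H]1OC3`: > 16000 nM

Both entries come from a functional assay on MCF7 cells (Homo sapiens) for inhibition, read by sulforhodamine B assay (on this read-out higher numbers stand for weaker inhibition and lower numbers for stronger inhibition), and neither is an exact number. Compound 2 stands only at a limit of the assay, > 16000 nM. Compound 1 also gives only a limit, > 8000 nM.

The next compound is compound 3 `O=C1C=C(N2CCCCC2)C(=O)c2c1nc1n2[C@H]2OC[C@@H](O)[C@H]2OC1`, which keeps the shared core and changes one group on a double-bonded ring carbon: piperidin-1-yl in place of dipropylamino on a double-bonded ring carbon. In words, piperidin-1-yl takes the place of dipropylamino, so an open pair of chains gives way to a six-membered non-aromatic ring.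

For the measured compounds named here, one measured step bears on this change, since it also alters the group on a double-bonded ring carbon: a step that the two limits leave unreadable from compound 1 to compound 2. It offers no size to carry over, so no step beyond the usual scatter is expected in this assay. The expectation therefore stays close to compound 2, with its limit of > 16000 nM.

For compound 3 the expected value is 16000 nM, with an estimated range from 7000 nM to 40000 nM. The expected size of the change is a number no higher from compound 2 to compound 3 (the limit leaves the size open).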

Compound 3, half-maximal inhibitory concentration: > 8000 nM
Compound 3: a limit, no number; the forecaster's own chance of this, stated with the estimate: 70%; the middle value lies beyond the limit too.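

In this assay compound 3 gives only a limit, > 8000 nM. For the compounds shown here, compound 1 and compound 2 also give only limits, so no step between compound 1, compound 2 and compound 3 can be read. The compounds shown leave open how strongly each one inhibits, and whether benzylamino, dipropylamino and piperidin-1-yl differ at all.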